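The source may hold more compounds than are shown below. What is called first, only, known or untested is meant among the compounds shown, and "the series" means these compounds.

Of the compounds shown here, three have been measured in an assay on isolated protein for inhibition of 2-Hydroxyacid oxidase 2 (Homo sapiens), tested at 1 uM; a lower number here means a weaker effect, a higher number a stronger effect of the compound at the concentration tested: compound 1 `Cc1n[nH]c(C(=O)O)c1Cc1ccc(C(F)(F)F)cc1` gives 9%, compound 2 `Cc1n[nH]c(C(=O)O)c1Cc1cccc(-c2ccccc2F)c1` gives 5%, and compound 3 `Cc1n[nH]c(C(=O)O)c1Cc1cc2ccccc2s1` gives 8%.

Compound 2 shows the lowest of the three numbers, but its gap to compound 3 and its gap to compound 1 both lie within the scatter, so all three sit at a weak level in this assay. Compound 4 `Cc1n[nH]c(C(=O)O)c1Cc1cccc(C(=O)O)c1` has not yet been measured there. It differs from compound 2 in one place: carboxy in place of 2-fluorophenyl on an aromatic carbon. Among the measured compounds shown here, with no step between measured compounds available, no change beyond the scatter is expected in this assay from this exchange. Compound 4 is therefore estimated at 10%, within 0% to 30%, an expected step of a number 5 percentage points higher from compound 2 to compound 4 (within the scatter).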

Compound 4, a percentage reported as inhibition, at one concentration (the size of the read-out at that concentration, not a potency): 3%
Compound 4: middle estimate off by 7 percentage points, on the high side; the measured number falls inside the stated range.
By their numbers in this assay, from the lowest: compounds 4, 2, 3 and 1 (each within the scatter of the next).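

In this assay, among the compounds shown here, exchanging 2-fluorophenyl for carboxy on an aromatic carbon, meta to a large group, gives a number 2 percentage points lower from compound 2 to compound 4 (within the scatter) as the first step that can be read at this position. Losing an aromatic ring and gaining a hydrogen-bond donor and acceptor therefore leaves the read-out at the same weak level. No measurement offered here explains this result. Going by these compounds, whether an amine, a methoxy group or a longer chain at this position would give a read-out beyond the scatter remains open. So does whether any change to the shared core would.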